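A few compounds are considered here, and "the series" means these few. Any claim that something is new, unique, unknown or untested is made for them only; others in the source may bear on it.

Measured so far:
- compound 1 `COCCNC(=O)Nc1cc2c(Nc3ccc(F)c(Cl)c3)ncnc2cc1O[C@H]1CCOC1`: 387 nM
- compound 2 `CN(C)CCCN(C)C(=O)Nc1cc2c(Nc3ccc(F)c(Cl)c3)ncnc2cc1O[C@H]1CCOC1`: 200 nM

Both values come from a functional assay on A-431 cells (Homo sapiens) for antiproliferative activity, read by sulforhodamine B assay, with a stated time of 72 h; a lower number here means a stronger inhibitor, a higher number a weaker inhibitor. Among the measured compounds shown here, compound 2 holds the lowest of the two numbers, though the only step to it, a 1.9-fold lower number from compound 1 to compound 2 (0.29 log units; within the scatter), is within the scatter, so no order between compound 1 and compound 2 can be read from it.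

Compound 3 `O=C(Nc1cc2c(Nc3ccc(F)c(Cl)c3)ncnc2cc1O[C@H]1CCOC1)N1CCC(CCO)CC1` is not yet measured. Against compound 2 the change is 4-(2-hydroxyethyl)piperidin-1-yl in place of (3-(dimethylamino)propyl)(methyl)amino on a carbonyl carbon. For the measured compounds named here, the one step that bears on it is the exchange at the same carbonyl carbon, a 1.9-fold lower number from compound 1 to compound 2 (0.29 log units; within the scatter), which did not move the number beyond the scatter. A second exchange of the amine portion of the urea, now bringing in a ring and a hydroxyl, is therefore expected to leave the number near that of compound 2, with no step beyond the scatter in either direction.

The expected step is a 1.3-fold higher number from compound 2 to compound 3 (0.10 log units; within the scatter). For compound 3 the estimate in this assay is 250 nM, with a range from 100 nM to 650 nM.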

Compound 3, half-maximal inhibitory concentration: 759 nM
Compound 3: the middle estimate sits 3.0-fold (0.48 log units) below what was measured, outside the stated range (above it).
By their numbers in this assay, from the lowest: compounds 2, 1 and 3 (each within the scatter of the next, the first and the last beyond it).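

On a carbonyl carbon whose other neighbours are an amide-type nitrogen, this assay now gives a step beyond the scatter: a 3.8-fold higher number from compound 2 to compound 3 (0.58 log units; beyond the scatter), as 4-(2-hydroxyethyl)piperidin-1-yl replaces (3-(dimethylamino)propyl)(methyl)amino. With (2-methoxyethyl)amino as the group replaced, the same entering group gives a 2.0-fold higher number from compound 1 to compound 3 (0.29 log units; within the scatter), so the exchange at this position registers against compound 2 only, while compound 1 stays within the scatter of both others. No measurement available accounts for the step to compound 3.

This single exchange changes the ring, the hydroxyl and the dimethylamino group together, so the contribution of each remains unresolved. Unsubstituted piperidin-1-yl and 4-(2-(dimethylamino)ethyl)piperidin-1-yl would separate these parts, and neither is among the compounds shown.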